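The source may report more compounds than this note shows. Statements on the series, on what has been measured and on what is new or still open speak of the compounds shown alone.

Among the compounds with values here, compound 2 `O=S(=O)(/C=C/c1ccc(O)c(O)c1)Cc1ccc(Cl)cc1` carries the higher of the two numbers so far in a functional assay on BV-2 cells (Mus musculus) for inhibition, read by Griess assay, with stated times of 3 h and 24 h (on this read-out higher numbers stand for weaker inhibition and lower numbers for stronger inhibition), where compound 2 gives 11700 nM, although its only neighbour, compound 1 `O=S(=O)(/C=C/c1ccc(O)c(O)c1)Cc1ccccc1`, which in this assay gives 11600 nM, sits within the scatter of it. Compound 3 `CC(C)(C)c1ccc(CS(=O)(=O)/C=C/c2ccc(O)c(O)c2)cc1` differs from compound 2 by tert-butyl in place of chloro on an aromatic carbon. Within the data shown here, the one step that bears on a change at this position is a 1.0-fold higher number from compound 1 to compound 2 (0.00 log units; within the scatter), which left the number where it was. Compound 3 is therefore expected to show a step of no change at the digits printed from compound 2 to compound 3 (within the scatter), nothing beyond the scatter. In this assay compound 3 is estimated at 11700 nM, with a range from 5000 nM to 28000 nM.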

Compound 3, half-maximal inhibitory concentration: 12600 nM
Estimate against measurement, compound 3: 1.1-fold (0.03 log units) below, within the range that was stated.
By their numbers in this assay, from the lowest: compounds 1, 2 and 3 (each within the scatter of the next).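

In this assay, tert-butyl in place of chloro gives a 1.1-fold higher number from compound 2 to compound 3 (0.03 log units; within the scatter), and tert-butyl in place of hydrogen gives a 1.1-fold higher number from compound 1 to compound 3 (0.04 log units; within the scatter). Hydrogen, chloro and tert-butyl, on an aromatic carbon para to a large group, thus all lie within the scatter of one another, and the all-carbon tert-butyl leaves the number where chloro did. No available evidence explains this insensitivity. Going by these compounds, whether an amine or a carboxylic acid at this carbon would move the number beyond the scatter remains open. So does the effect of any such group elsewhere on the shared core.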